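A few compounds are considered here, and "the series" means these few. Any claim that something is new, unique, unknown or untested is made for them only; others in the source may bear on it.

Compound 1, `Nc1n[nH]c2cccc(C#Cc3cccc(NC(=O)c4cccc(C(F)(F)F)c4)c3)c12`, is measured in a functional assay on K562 cells (Homo sapiens) for inhibition, read by MTT assay, with a stated time of 72 h (a higher number here means a weaker inhibitor of growth, a lower number a stronger inhibitor of growth), where compound 1 gives 1540 nM. Compound 2, `Nc1n[nH]c2cccc(C#Cc3cccc(NC(=O)c4cc(C(F)(F)F)cc(C(F)(F)F)c4)c3)c12`, carries one more group: trifluoromethyl in place of hydrogen on an aromatic carbon. In this assay compound 2 gives > 10000 nM, which is a limit of the assay rather than a number. The step of an at least 6.4-fold higher number from compound 1 to compound 2 (0.81 log units; beyond the scatter) is therefore open-ended, as the limit of > 10000 nM in this assay, at which 1 of the 3 values shown sits, shows. Compound 3, `Nc1n[nH]c2cccc(C#Cc3cccc(C(=O)Nc4cccc(C(F)(F)F)c4)c3)c12`, has the same atoms as compound 1 joined differently; how the two cores differ is not broken down here. In this assay compound 3 gives 3470 nM. Compound 4, `Nc1n[nH]c2cccc(C#Cc3cccc(C(=O)Nc4cc(C(F)(F)F)cc(C(F)(F)F)c4)c3)c12`, is not yet measured; it differs from compound 3 by the same change, (trifluoromethyl in place of hydrogen on an aromatic carbon). The step from compound 3 to compound 4 is expected to be a 7.2-fold higher number from compound 3 to compound 4 (0.86 log units; beyond the scatter), resting on what an at least 6.4-fold higher number from compound 1 to compound 2 (0.81 log units; beyond the scatter) showed. Compound 4 is thus estimated at 25000 nM in this assay, between 7000 nM and 80000 nM.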

Compound 4, concentration for 50% growth inhibition: 520 nM
Beside the measured number, compound 4's estimate is 48-fold (1.68 log units) above it; measured number outside the range, below it.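

In this assay, trifluoromethyl in place of hydrogen on an aromatic carbon gives a 6.7-fold lower number from compound 3 to compound 4 (0.82 log units; beyond the scatter), so growth inhibition becomes stronger on this core, whereas the same change weakened it on the core of compound 1. The change therefore does not carry over from one core to the other in these two pairs: the same change on two cores in this assay, an at least 6.4-fold higher number (0.81 log units; beyond the scatter) from compound 1 to compound 2 and a 6.7-fold lower number (0.82 log units; beyond the scatter) from compound 3 to compound 4, at least 43-fold (1.63 log units) apart, beyond the scatter of two such steps. From the compounds shown here alone, this shows that the direction of the step differs between the two cores, but it does not show what in the cores sets that direction, and the size of the earlier step stays open-ended, as compound 2 stands at a limit of the assay: the limit of > 10000 nM in this assay, at which 1 of the 4 values shown sits.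

The compounds shown leave open whether another group on the same aromatic carbon, such as a methoxy group or an amine, would also split between the two cores.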